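Thiophen-3-yl in place of phenyl: working notes

This account rests on a few compounds, and the source may have more. Where it says the series, first, only, none or still open, it means among the compounds named here.

Measured in a functional assay on MOLT-4 cells (Homo sapiens) for antiproliferative activity; on this read-out higher numbers stand for weaker inhibition and lower numbers for stronger inhibition:
- compound 1 `COc1cc(C(=O)c2sc(-c3ccc(Br)cc3)cc2N)cc(OC)c1OC`: 92 nM
- compound 2 `COc1cc(C(=O)c2sc(-c3ccccc3)cc2N)cc(OC)c1OC`: 5.3 nM

Compound 2 holds the lower of the two numbers. Compound 3 `COc1cc(C(=O)c2sc(-c3ccsc3)cc2N)cc(OC)c1OC` is the next to be read, with thiophen-3-yl in place of phenyl on an aromatic carbon. Going by the values given here, one measured step bears on this aryl group: a 17-fold lower number from compound 1 to compound 2 (1.24 log units; beyond the scatter), a large step for hydrogen in place of bromo. That step changes a group on the ring, not the ring itself, so it is only a loose guide. No step beyond the scatter is expected in this assay, with at most a slight rise in the number. The expected step is a 1.5-fold higher number from compound 2 to compound 3 (0.18 log units; within the scatter). For compound 3 the estimate is 8 nM, within an expected range of 2.5 nM to 30 nM.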

Compound 3, half-maximal inhibitory concentration: 8.8 nM
Compound 3: the middle estimate sits 1.1-fold (0.04 log units) below what was measured; measured number inside the range.
By their numbers in this assay, from the lowest: compounds 2 and 3 (each within the scatter of the next); then compound 1.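

In this assay this position accepts a change of the ring itself, not only of a group on it: thiophen-3-yl in place of phenyl gives a 1.7-fold higher number from compound 2 to compound 3 (0.22 log units; within the scatter) and so stays within the scatter. Thiophen-3-yl in place of 4-bromophenyl gives a 10-fold lower number from compound 1 to compound 3 (1.02 log units; beyond the scatter) and thus separates compound 3 from the brominated compound as clearly as compound 2. Nothing at hand explains either step.

Still open, going by these compounds, is whether thiophen-2-yl or pyridinyl would also hold the number near those of compound 2 and compound 3. Also open, on these data alone, is whether fluoro or an amine on the phenyl ring would cost as much as bromo.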